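Phenyl to Pyridin-2-yl on a Ring Amine Nitrogen

A few compounds are considered here, and "the series" means these few. Any claim that something is new, unique, unknown or untested is made for them only; others in the source may bear on it.

Of the compounds shown here, two built on a shared core have so far been measured in a functional assay on HepG2 cells (Homo sapiens) for antiproliferative activity, read by MTT assay, with a stated time of 48 h; on this read-out lower numbers stand for stronger inhibition and higher numbers for weaker inhibition. Compound 1 `S=c1oc(-c2ccc3c(c2)OCCO3)nn1CN1CCN(C(c2ccccc2)c2ccccc2)CC1` gives 9120 nM. Compound 2 `S=c1oc(-c2ccc3c(c2)OCCO3)nn1CN1CCN(c2ccccc2)CC1` is reported only as a limit of the assay, > 50000 nM. Of the two values shown, compound 2 is the one that sits at the limit of > 50000 nM in this assay, at which 1 of the 2 values shown sits, so it stands not at a measured number but at the boundary of what the assay reports. Compound 3 `S=c1oc(-c2ccc3c(c2)OCCO3)nn1CN1CCN(c2ccccn2)CC1` has not yet been measured; it differs from compound 2 in a single place: pyridin-2-yl in place of phenyl on an amine nitrogen in a ring. For the measured compounds named here, no pair of measured compounds differing in one place is available, so the size of such a change is not known from these data. In this assay the expected step that the limit leaves unreadable from compound 2 to compound 3 is none beyond the usual scatter. Compound 3 is accordingly expected to give about 60000 nM, with a range of 15000 nM to 200000 nM, and most likely to be reported again only as a limit.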

Compound 3, half-maximal inhibitory concentration: 11400 nM
Compound 3: middle estimate off by 5.3-fold (0.72 log units), on the high side, outside the stated range (below it).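

In this assay, for the compounds shown here, the exchange of phenyl for pyridin-2-yl on the amine nitrogen in the ring is the first single change that can be read, and it gives an at least 4.3-fold lower number from compound 2 to compound 3 (0.64 log units; beyond the scatter). The position is therefore sensitive to the make-up of the aromatic ring it carries: a single ring nitrogen, which brings one hydrogen-bond acceptor by count, separates a compound reported only as a limit from one with a measured number. The step has only a minimum size, since its starting point, compound 2, stands at a limit of the assay: the limit of > 50000 nM in this assay, at which 1 of the 3 values shown sits.

On these data alone, it remains open whether pyridin-3-yl, pyridin-4-yl or pyrimidin-2-yl on the same nitrogen would give a similar number. The compounds shown also cannot tell how far the step extends beyond its minimum.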